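The compounds below may be only part of what the source reports. "The series", "measured", "known", "first", "only" and "open" are said of these compounds alone.

In a functional assay on PANC-1 cells (Homo sapiens), read by microscopy, crystal violet staining and transwell migration, with a stated time of 18 h, in the presence of a further agent that is not named here (on this read-out higher numbers stand for weaker inhibition and lower numbers for stronger inhibition), compound 1 (`CCc1nc(-c2ccc(OC(F)F)cc2)n(-c2cccc(C(=O)NCCCCc3ccccc3)c2)n1`) gives 830 nM and compound 2 (`CCc1nc(-c2ccc(OC)nc2)n(-c2cccc(C(=O)NCCCCc3ccccc3)c2)n1`) gives 810 nM. These two values lie within the usual scatter of each other, so compound 2 cannot be ranked apart from compound 1. Compound 3 (`CCc1nc(-c2ccc(OC)cn2)n(-c2cccc(C(=O)NCCCCc3ccccc3)c2)n1`) has the same atoms as compound 2, joined differently: 5-methoxypyridin-2-yl in place of 6-methoxypyridin-3-yl on an aromatic carbon. The swap is on an aromatic carbon of a five-membered aromatic ring with 3 nitrogen. Going by the values given here, the only measured step, a 1.0-fold lower number from compound 1 to compound 2 (0.01 log units; within the scatter), came with 6-methoxypyridin-3-yl in place of 4-(difluoromethoxy)phenyl on that same carbon. Among the compounds with values here, it is a different swap, so it is only indirect evidence, and no measured step tests this rearrangement. Starting from compound 2 at 810 nM, no step beyond the scatter is expected in this assay, and no direction can be favoured. The estimate for compound 3 is 850 nM, with an expected range of 350 nM to 2000 nM. This estimate amounts to an expected 1.0-fold higher number from compound 2 to compound 3 (0.02 log units; within the scatter).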

Compound 3, half-maximal inhibitory concentration: 120 nM
The estimate for compound 3 lay 7.1-fold (0.85 log units) above the measured number; the measured number lies below the stated range.
By their numbers in this assay, from the lowest: compound 3; then compounds 2 and 1 (each within the scatter of the next).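

In this assay, rearranging the same atoms of the pyridine ring gives a 6.8-fold lower number from compound 2 to compound 3 (0.83 log units; beyond the scatter), so this aromatic carbon of the shared core responds to how the attached group is joined, not only to which atoms it contains. Replacing 4-(difluoromethoxy)phenyl with 5-methoxypyridin-2-yl at the same carbon gives a 6.9-fold lower number from compound 1 to compound 3 (0.84 log units; beyond the scatter), whereas the earlier swap to 6-methoxypyridin-3-yl produced no step beyond the scatter. No measurement here gives a reason for this difference.

From the compounds shown here alone, it remains open whether the methoxy group is needed, which a pyridin-2-yl ring with no substituent, or with an amine or a longer ether chain in its place, would help to settle. Going by these compounds, whether the step carries over to other cores also remains open, since all three compounds share the ethyl group and the same amide side chain.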